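Replacing the Benzofuran Amide with a Cinnamoyl Group

The source may report more compounds than this note shows. Statements on the series, on what has been measured and on what is new or still open speak of the compounds shown alone.

Compound 3 `CN1[C@@H]2c3[nH]c4ccccc4c3C[C@H]1[C@H](C#N)N1[C@@H](CNC(=O)c3cc4ccccc4o3)c3[nH]c4ccccc4c3C[C@@H]21` bears a benzofuran-derived amide on the shared core, and in a functional assay on BGC-823 cells (Homo sapiens) for cytotoxicity, read by MTT assay, with a stated time of 72 h (on this read-out higher numbers stand for weaker inhibition and lower numbers for stronger inhibition), compound 3 gives 210 nM. This number sits at the low end of the three measured. Compound 1 `COc1ccc(C(=O)NC[C@H]2c3[nH]c4ccccc4c3C[C@H]3[C@H]4c5[nH]c6ccccc6c5C[C@@H]([C@H](C#N)N23)N4C)cc1` gives 320 nM, and compound 2 `CCc1ccc(C(=O)NC[C@H]2c3[nH]c4ccccc4c3C[C@H]3[C@H]4c5[nH]c6ccccc6c5C[C@@H]([C@H](C#N)N23)N4C)cc1` gives 660 nM; the corresponding steps were a 1.5-fold lower number from compound 1 to compound 3 (0.18 log units; within the scatter), within the scatter, and a 3.1-fold lower number from compound 2 to compound 3 (0.50 log units; beyond the scatter), beyond it. Compound 4 `CN1[C@@H]2c3[nH]c4ccccc4c3C[C@H]1[C@H](C#N)N1[C@@H](CNC(=O)/C=C/c3ccccc3)c3[nH]c4ccccc4c3C[C@@H]21` differs from compound 3 by 2-phenylethenyl in place of 1-benzofuran-2-yl on a carbonyl carbon. Both amide replacements seen so far, a 1.5-fold lower number from compound 1 to compound 3 (0.18 log units; within the scatter) and a 3.1-fold lower number from compound 2 to compound 3 (0.50 log units; beyond the scatter), were modest at most, so this further amide swap is expected to shift this assay only a little, with a 1.4-fold higher number from compound 3 to compound 4 (0.15 log units; within the scatter) expected. Compound 4 is therefore estimated at 300 nM, within 120 nM to 800 nM.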

Compound 4, half-maximal inhibitory concentration: 4300 nM
Compound 4: middle estimate off by 14-fold (1.16 log units), on the low side; measured number outside the range, above it.
By their numbers in this assay, from the lowest: compounds 3 and 1 (each within the scatter of the next); then compound 2; then compound 4.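

The earlier swaps on this carbonyl carbon moved the number modestly at most, but 2-phenylethenyl gives a 20-fold higher number from compound 3 to compound 4 (1.31 log units; beyond the scatter). The shift is also large against the 4-methoxyphenyl amide, with a 13-fold higher number from compound 1 to compound 4 (1.13 log units; beyond the scatter), and remains clear but modest against the 4-ethylphenyl amide, with a 6.5-fold higher number from compound 2 to compound 4 (0.81 log units; beyond the scatter). The data shown here offer nothing that explains this jump. Open, going by these compounds, is whether the double bond outside the aromatic ring matters, which a saturated 2-phenylethyl group on the same carbonyl carbon would test.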